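The source may report more compounds than this note shows. Statements on the series, on what has been measured and on what is new or still open speak of the compounds shown alone.

Measured so far:
compound 1 `CCC(CC)C(/C=C1\OC(=O)NC1=O)c1ccc(-c2ccc3cccc(F)c3c2)[nH]c1=O`: 23 nM
compound 2 `O=C1NC(=O)/C(=C/C(Cc2ccccc2)c2ccc(-c3ccc4cccc(F)c4c3)[nH]c2=O)O1`: 200 nM

Within the data shown here, in a functional assay on CHO cells for antagonist activity at prostaglandin E2 receptor EP3 subtype (Homo sapiens), read by cAMP accumulation, with a stated time of 30 min (on this read-out higher numbers stand for weaker inhibition and lower numbers for stronger inhibition), compound 2 holds the higher of the two numbers; the one step in hand is an 8.7-fold higher number from compound 1 to compound 2 (0.94 log units; beyond the scatter), a modest rise on moving away from the branched pentan-3-yl group.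

Compound 3 `O=C1NC(=O)/C(=C/C(c2ccccc2)c2ccc(-c3ccc4cccc(F)c4c3)[nH]c2=O)O1` carries the change (phenyl in place of benzyl on a saturated chain carbon bound to an aromatic carbon and a double-bonded chain carbon). Among the measured compounds shown here, no measured step covers phenyl against benzyl at this position, so the step is expected to be small, within or near the scatter, with a slight lean toward a lower number as the group moves further from benzyl; compound 3 is expected at a 1.3-fold lower number from compound 2 to compound 3 (0.12 log units; within the scatter). The estimate for compound 3 is 150 nM, ranging from 50 nM to 500 nM.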

Compound 3, half-maximal inhibitory concentration in the prostaglandin E2 receptor EP3 subtype assay: 190 nM
Compound 3: middle estimate off by 1.3-fold (0.10 log units), on the low side; measured number inside the range.
By their numbers in the prostaglandin E2 receptor EP3 subtype assay, from the lowest: compound 1; then compounds 3 and 2 (each within the scatter of the next).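

In the prostaglandin E2 receptor EP3 subtype assay the step is a 1.1-fold lower number from compound 2 to compound 3 (0.02 log units; within the scatter) and so benzyl and phenyl on this saturated chain carbon are not told apart, while the step of an 8.3-fold higher number from compound 1 to compound 3 (0.92 log units; beyond the scatter) leaves both aromatic groups on the same side of pentan-3-yl. The pair does separate in a physicochemical assay for solubility, in phosphate buffer, measured as kinetic solubility (on this read-out lower numbers stand for lower solubility and higher numbers for higher solubility), where compound 2 gives 9100 nM and compound 3 gives 32800 nM in favour of phenyl: the measured solubility of compound 2, 9100 nM, and of compound 3, 32800 nM, a 3.6-fold higher number (0.56 log units; beyond the scatter).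

Open, going by these compounds, is whether a cyclohexyl group or a longer branched chain at this position would match the number of compound 1. Also open, on these data alone, is how an amine or a carboxylic acid there would read in both assays.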